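The compounds below may be only part of what the source reports. "The series", "measured", "known", "first", "only" and "open" are said of these compounds alone.

Working notes on the series, read in a functional assay on NCI-H460 cells (Homo sapiens) for cytotoxicity, read by MTT assay, with a stated time of 72 h; a higher number here means a weaker inhibitor, a lower number a stronger inhibitor.

Compound 1 `COc1cc2c(Oc3ccc(NC(=O)c4cc(-c5ccc(C)cc5)ccn4)cc3F)ccnc2cc1OCCCN1CCCC1` and compound 2 `COc1cc2c(Oc3ccc(NC(=O)c4cc(-c5ccc(C)cc5)ccn4)cc3F)ccnc2cc1OCCCN1CCCCC1` share one core and differ only in the amine at the end of the chain. In this assay compound 1 gives 160 nM, and compound 2 gives 160 nM. The step of no change at the digits printed from compound 2 to compound 1 (within the scatter) is the change (pyrrolidin-1-yl in place of piperidin-1-yl on a saturated chain carbon, three bonds along the chain from an oxygen on an aromatic ring); the two values sit within the scatter of each other, so nothing is read into their order.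

Compound 3 `COc1cc2c(Oc3ccc(NC(=O)c4nccc(-c5ccccc5)n4)cc3F)ccnc2cc1OCCCN1CCCCC1` carries the piperidin-1-yl end of compound 2 on a different core; how the two cores differ is not broken down here. In this assay compound 3 gives 330 nM, the highest of the three numbers and beyond the scatter from both compound 1 and compound 2.

Compound 4 `COc1cc2c(Oc3ccc(NC(=O)c4nccc(-c5ccccc5)n4)cc3F)ccnc2cc1OCCCN1CCCC1` is not yet measured. It stands to compound 3 as compound 1 stands to compound 2: the change (pyrrolidin-1-yl in place of piperidin-1-yl on a saturated chain carbon, three bonds along the chain from an oxygen on an aromatic ring), at the same place in the same words as the change from compound 2 to compound 1, so it is the same change made on the other core. The step from compound 3 to compound 4 is expected to be no change at the digits printed from compound 3 to compound 4 (within the scatter), resting on the step of no change at the digits printed from compound 2 to compound 1 (within the scatter), which showed no change within the scatter for this exchange of amines on the core of compound 2. Whether the core of compound 3 answers the same way is not known from these three measurements; the scatter itself is the main uncertainty. In this assay compound 4 is therefore estimated at 330 nM, with the expected range 170 nM to 650 nM.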

Compound 4, half-maximal inhibitory concentration: 1120 nM
Beside the measured number, compound 4's estimate is 3.4-fold (0.53 log units) below it; the whole stated range lies below it.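

In this assay, pyrrolidin-1-yl in place of piperidin-1-yl on the core of compound 3 gives a 3.4-fold higher number from compound 3 to compound 4 (0.53 log units; beyond the scatter), so here the shorter-ring amine goes with the weaker inhibitor. The exchange therefore does not carry over unchanged between these two cores, and the result on the core of compound 2 does not predict the result on the core of compound 3: the same change on two cores in this assay, no change at the digits printed (within the scatter) from compound 2 to compound 1 and a 3.4-fold higher number (0.53 log units; beyond the scatter) from compound 3 to compound 4, 3.4-fold (0.53 log units) apart, beyond the scatter of two such steps

This rests on a single matched pair on each core, so it shows that the outcome of this exchange differs between these two cores, but it does not show which feature of the cores accounts for the difference, why the difference arises, or how the exchange would behave on any third core.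

Open, on these data alone, is whether another amine at the end of the same chain, such as morpholin-4-yl or dimethylamino, would stay level on the core of compound 2 and lose ground on the core of compound 3 as pyrrolidin-1-yl does. Also open, as far as these compounds go, is whether the gap between the two cores persists with a shorter chain, such as 2-(pyrrolidin-1-yl)ethyl in place of 3-(pyrrolidin-1-yl)propyl.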